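Shortening the Sulfur Chain: From Chlorobenzyl to Propyl

The source may hold more compounds than are shown below. What is called first, only, known or untested is meant among the compounds shown, and "the series" means these compounds.

Compound 1, `CCCCSc1n[nH]c(-n2[se]c3ccccc3c2=O)n1`, gives 12500 nM in a functional assay on A549 cells (Homo sapiens) for antiproliferative activity, read by CCK-8 assay, with a stated time of 48 h; on this read-out lower numbers stand for stronger inhibition and higher numbers for weaker inhibition.
Compound 2, `Cc1ccccc1CSc1n[nH]c(-n2[se]c3ccccc3c2=O)n1`, gives 9720 nM in this assay.
Compound 3, `O=c1c2ccccc2[se]n1-c1nc(SCc2ccc(Cl)cc2)n[nH]1`, gives 42100 nM in this assay.

Compound 3 has the highest number of the three: a 3.4-fold higher number from compound 1 to compound 3 (0.53 log units; beyond the scatter) and a 4.3-fold higher number from compound 2 to compound 3 (0.64 log units; beyond the scatter), both beyond the scatter, while a 1.3-fold lower number from compound 1 to compound 2 (0.11 log units; within the scatter) stays within it. Compound 4, `CCCSc1n[nH]c(-n2[se]c3ccccc3c2=O)n1`, differs from compound 3 by ethyl in place of 4-chlorophenyl on a saturated chain carbon bound to a sulfur. This change nearly reverses the step from compound 1 to compound 3, which was a 3.4-fold higher number from compound 1 to compound 3 (0.53 log units; beyond the scatter), so the number is expected to fall by about that amount, back toward compound 1. The estimate for compound 4 in this assay is 14000 nM, with a range from 6000 nM to 35000 nM. This expected change reads as a 3.0-fold lower number from compound 3 to compound 4 (0.48 log units; beyond the scatter).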

Compound 4, half-maximal inhibitory concentration: 45500 nM
Beside the measured number, compound 4's estimate is 3.3-fold (0.51 log units) below it, and the stated range ends below it.
By their numbers in this assay, from the lowest: compounds 2 and 1 (each within the scatter of the next); then compounds 3 and 4 (each within the scatter of the next).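

Putting ethyl in place of 4-chlorophenyl, a short chain for a ring, gives a 1.1-fold higher number from compound 3 to compound 4 (0.03 log units; within the scatter) and so shows that having a ring here does not by itself set the number. Removing a single methyl from the chain end, by contrast, gives a 3.6-fold higher number from compound 1 to compound 4 (0.56 log units; beyond the scatter) even though the change is small. Going to ethyl from 2-methylphenyl gives a 4.7-fold higher number from compound 2 to compound 4 (0.67 log units; beyond the scatter) in the same direction. No evidence here explains these shifts. On these data alone, whether a longer chain such as hexyl, or an amine at the chain end, would bring a lower number stays open.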